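Aryl Variation on a Sulfonylamide Thiazolone Series

The compounds below may be only part of what the source reports. "The series", "measured", "known", "first", "only" and "open" are said of these compounds alone.

Measured compounds:
- compound 1, `COc1ccc(/C=C2\SC(N[C@H](C(=O)NS(=O)(=O)c3ccc(C)cc3)C(C)C)=NC2=O)cc1`: 20.3 ug/mL
- compound 2, `Cc1ccc(S(=O)(=O)NC(=O)[C@@H](NC2=NC(=O)/C(=C/c3ccccc3Cl)S2)C(C)C)cc1`: 11.9 ug/mL
- compound 3, `Cc1ccc(S(=O)(=O)NC(=O)[C@H](CC(C)C)NC2=NC(=O)/C(=C/c3ccccc3F)S2)cc1`: 15.3 ug/mL

All three were read in a functional assay on PC-3 cells (Homo sapiens) for antiproliferative activity, read by MTT assay, with a stated time of 48 h; on this read-out higher numbers stand for weaker inhibition and lower numbers for stronger inhibition. Compound 2 gives 11.9 ug/mL in this assay, and its separation from the other two is small: the move a 1.7-fold lower number from compound 1 to compound 2 (0.23 log units; within the scatter), which replaces 4-methoxyphenyl with 2-chlorophenyl on the double-bonded chain carbon, stays inside the scatter, and the values of compound 2 and compound 3 are likewise within the scatter of one another. Going by the values given here, no pair here is resolved.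

Compound 4, `COc1ccccc1/C=C1\SC(N[C@H](C(=O)NS(=O)(=O)c2ccc(C)cc2)C(C)C)=NC1=O`, is not yet measured. Relative to compound 2 the change is methoxy in place of chloro on an aromatic carbon. Among the compounds with values here, only one measured step touches the same aryl position, the move from compound 1 to compound 2, and it was within the scatter despite swapping both the group and its place on the ring. With that single precedent, and no measured case of a methoxy group at this position, nothing argues for a step beyond the scatter in either direction.

The expected step of a 1.2-fold higher number from compound 2 to compound 4 (0.07 log units; within the scatter) is therefore estimated to be small. Compound 4 is expected to give about 14 ug/mL in this assay, with a range from 7 ug/mL to 28 ug/mL.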

Compound 4, half-maximal inhibitory concentration: 15 ug/mL
Compound 4: the middle estimate sits 1.1-fold (0.03 log units) below what was measured; low and high end bracket the measured number.
By their numbers in this assay, from the lowest: compounds 2, 4, 3 and 1 (each within the scatter of the next).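

In this assay, going by these compounds alone, methoxy in place of chloro on an aromatic carbon ortho to a large group gives a 1.3-fold higher number from compound 2 to compound 4 (0.10 log units; within the scatter) and is the first measured exchange of one group for another with the place held fixed. The exchange of 4-methoxyphenyl for 2-methoxyphenyl gives a 1.4-fold lower number from compound 1 to compound 4 (0.13 log units; within the scatter) and adds the complementary case, in which the group is held and its place on the ring is changed, so the two changes combined in the earlier aryl step can now be read separately, and neither is resolved from the scatter. Nothing available accounts for the size of either step.

Whether any group on this aromatic ring can move the number beyond the scatter remains open, since an amine or a carboxylic acid at this place, for example, does not appear among the compounds shown. Compound 3 differs from each of the others in more than one place, so the contribution of its chain cannot be separated from that of its 2-fluorophenyl group, and a longer chain at that position is likewise absent from this set.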